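The source may report more compounds than this note shows. Statements on the series, on what has been measured and on what is new or still open speak of the compounds shown alone.

Measured in a functional assay on U-937 cells (Homo sapiens) for cytotoxicity, read by MTT assay, with a stated time of 3 days; on this read-out higher numbers stand for weaker inhibition and lower numbers for stronger inhibition:
- compound 1 `N#Cc1c(Nc2ccccc2)nc(SCc2nc3ccccc3[nH]2)nc1-c1ccccc1`: 3.28 nM
- compound 2 `CN1CCN(c2nc(SCc3nc4ccccc4[nH]3)nc(-c3ccccc3)c2C#N)CC1`: 6.75 nM
- compound 3 `N#Cc1c(-c2ccccc2)nc(SCc2nc3ccccc3[nH]2)nc1N1CCN(S(=O)(=O)c2ccccc2)CC1`: 6.2 nM

In this assay, compound 3 at 6.2 nM lies within the scatter of both of the other measured compounds. Among the measured compounds shown here, the only step beyond the scatter in this small set is the modest 2.1-fold higher number from compound 1 to compound 2 (0.31 log units; beyond the scatter), where 4-methylpiperazin-1-yl takes the place of anilino on an aromatic carbon.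

The unmeasured compound 4 `N#Cc1c(-c2ccccc2)nc(SCc2nc3ccccc3[nH]2)nc1N1CCN(S(=O)(=O)c2ccccc2[N+](=O)[O-])CC1` differs from compound 3 in one place, with phenylsulfonyl becoming (2-nitrophenyl)sulfonyl: nitro in place of hydrogen on an aromatic carbon. The nitro stands on an aromatic carbon of a six-membered aromatic ring of carbon only, ortho to a large group.

For the measured compounds named here, no measured step shows a change on that ring, and no measured compound carries a nitro. The closest evidence is a 1.1-fold lower number from compound 2 to compound 3 (0.04 log units; within the scatter), which replaces methyl with the whole phenylsulfonyl on an amine nitrogen in a ring and stays within the scatter. The smaller addition in compound 4 is therefore expected to produce no step beyond the scatter in this assay. The expected step is a 1.0-fold lower number from compound 3 to compound 4 (0.01 log units; within the scatter). Compound 4 is estimated at 6 nM, with an expected range from 2.5 nM to 15 nM.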

Compound 4, half-maximal inhibitory concentration: 3.28 nM
Beside the measured number, compound 4's estimate is 1.8-fold (0.26 log units) above it, within the range that was stated.
By their numbers in this assay, from the lowest: compounds 1, 4, 3 and 2 (each within the scatter of the next, the first and the last beyond it).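

Among the compounds shown here, on a six-membered aromatic ring of carbon only, ortho to a large group, nitro in place of hydrogen gives a 1.9-fold lower number from compound 3 to compound 4 (0.28 log units; within the scatter) in this assay and thus adds 3 heavy atoms at this place with no step beyond the scatter, the first reading of any change on that ring. Measured against the methyl of compound 2, the (2-nitrophenyl)sulfonyl group gives a 2.1-fold lower number from compound 2 to compound 4 (0.31 log units; beyond the scatter) and passes beyond the scatter, though only modestly, whereas the unsubstituted phenylsulfonyl group gives a 1.1-fold lower number from compound 2 to compound 3 (0.04 log units; within the scatter) and stays within it. Nothing measured here gives a reason for either step.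

The compounds shown leave open whether an amine, a carboxylic acid or a methoxy group on this same aromatic carbon would also stay within the scatter of compound 3, since nitro is the only group other than hydrogen seen there. They also leave open how a nitro on another carbon of that ring would read, and whether replacing the phenyl of the sulfonyl group with a longer alkyl chain would keep the number of compound 4 in this assay or move it beyond the scatter.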